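Aryl swap at the pyrimidine position: compound 3 to compound 4

This account rests on a few compounds, and the source may have more. Where it says the series, first, only, none or still open, it means among the compounds named here.

Values in a functional assay on HCT-116 cells (Homo sapiens) for inhibition, read by MTT assay, with a stated time of 48 h; on this read-out lower numbers stand for stronger inhibition and higher numbers for weaker inhibition:
- compound 1 `COc1cc(-c2cc(-c3ccc(Cl)cc3)nc(-c3ccccc3)n2)cc(OC)c1OC`: 7980 nM
- compound 2 `COc1cc(-c2cc(-c3ccc(Br)cc3)nc(-c3ccccc3)n2)cc(OC)c1OC`: 4320 nM
- compound 3 `COc1cc(-c2cc(-c3ccc(C)cc3)nc(-c3ccccc3)n2)cc(OC)c1OC`: 15700 nM

Compound 3 sits at the high end of these three numbers. Its separation is a 3.6-fold higher number from compound 2 to compound 3 (0.56 log units; beyond the scatter), while a 2.0-fold higher number from compound 1 to compound 3 (0.29 log units; within the scatter) stays within the scatter.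

Compound 4 `COc1ccc(-c2cc(-c3cc(OC)c(OC)c(OC)c3)nc(-c3ccccc3)n2)c(OC)c1` is the next to be read. The change is 2,4-dimethoxyphenyl in place of 4-methylphenyl on an aromatic carbon.

The measured steps bear on this only indirectly, since they exchange only chloro, bromo and methyl on an aromatic carbon. Besides the two steps above, a 1.8-fold lower number from compound 1 to compound 2 (0.27 log units; within the scatter) is also within the scatter. The largest of the three is modest, and none of them introduces a 2,4-dimethoxyphenyl group. No large shift is therefore expected, only a slight lean towards the lower numbers of the series. The expected step is a 1.6-fold lower number from compound 3 to compound 4 (0.20 log units; within the scatter). For compound 4 the estimated value is 10000 nM, with an expected range of 3500 nM to 30000 nM.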

Compound 4, half-maximal inhibitory concentration: > 25000 nM
Compound 4 gave a limit, no number; the forecaster's own chance of this, stated with the estimate: 10%; middle value at least 2.5-fold (0.39 log units) from the limit.
By their numbers in this assay, from the lowest: compounds 2, 1 and 3 (each within the scatter of the next, the first and the last beyond it). At a limit, above all of these: compound 4.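

Compound 4 reads only as a limit, not a number, in this assay: the limit of > 25000 nM in this assay, at which 1 of the 4 values shown sits. The earlier steps shown here exchanged only chloro, bromo and methyl, whereas this change replaces the whole aryl group, and against the halogenated aryl groups 2,4-dimethoxyphenyl gives no gain: the read-out shows an at least 5.7-fold higher number from compound 2 to compound 4 (0.76 log units; beyond the scatter) and an at least 3.1-fold higher number from compound 1 to compound 4 (0.49 log units; beyond the scatter), both beyond the scatter. Against 4-methylphenyl the result is less decisive, since an at least 1.5-fold higher number from compound 3 to compound 4 (0.20 log units; that floor lies within the scatter) gives only a floor, so these values do not separate the 2,4-dimethoxyphenyl and 4-methylphenyl groups.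

On these data alone, how far compound 4 lies past its limit remains open. Also open, as far as these compounds go, is whether an aryl group carrying an amine or a carboxylic acid at this position would give a lower number than the 4-bromophenyl group of compound 2.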